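Hydantoin cap series: removing the benzyl aryl ring

The source may hold more compounds than are shown below. What is called first, only, known or untested is meant among the compounds shown, and "the series" means these compounds.

Of the compounds shown here, two have numbers so far. Compound 1 `O=C(CCC1C(=O)N(c2ccc(Cl)cc2)C(=O)N1Cc1ccc(Br)cc1)NCc1ccc(C(=O)NO)cc1` gives 16.5 nM in an assay on isolated protein for inhibition of protein deacetylase HDAC6 (Homo sapiens), read by fluorescence, with stated times of 5 min and 60 min; a lower number here means a stronger inhibitor, a higher number a weaker inhibitor. Compound 2 `O=C(CCC1C(=O)N(c2ccc(Cl)cc2)C(=O)N1Cc1ccccc1)NCc1ccc(C(=O)NO)cc1` gives 12.7 nM in this assay. Among the measured compounds shown here, the one measured step, a 1.3-fold lower number from compound 1 to compound 2 (0.11 log units; within the scatter), stays inside the usual scatter, so compound 2 stands at the lowest of the two numbers without being separated from compound 1.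

Compound 3 `CN1C(=O)N(c2ccc(Cl)cc2)C(=O)C1CCC(=O)NCc1ccc(C(=O)NO)cc1` carries the change (hydrogen in place of phenyl on a saturated chain carbon bound to an amide-type nitrogen in a ring). For the measured compounds named here, no measured step touches the same part of the molecule: the step from compound 1 to compound 2 alters only a substituent on the phenyl that compound 3 loses entirely, and it was flat. With the hydroxamic acid side untouched, the working expectation is a modest rise in number. The step from compound 2 to compound 3 is estimated at a 2.2-fold higher number from compound 2 to compound 3 (0.34 log units; beyond the scatter). Compound 3 is expected to give 28 nM in this assay, with a range from 9 nM to 90 nM.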

Compound 3, half-maximal inhibitory concentration: 11.8 nM
Beside the measured number, compound 3's estimate is 2.4-fold (0.38 log units) above it; the measured number falls inside the stated range.
By their numbers in this assay, from the lowest: compounds 3, 2 and 1 (each within the scatter of the next).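

Working notes: cutting benzyl to methyl, hydrogen in place of phenyl on a saturated chain carbon bound to an amide-type nitrogen in a ring, gives a 1.1-fold lower number from compound 2 to compound 3 (0.03 log units; within the scatter) in this assay, and the wider cut gives a 1.4-fold lower number from compound 1 to compound 3 (0.15 log units; within the scatter). The earlier step showed only that a bromo on this phenyl could be replaced by hydrogen within the scatter; these steps show the same for losing the whole phenyl, so across compound 1, compound 2 and compound 3 this aromatic ring makes no readable difference to the number. No evidence at hand bears on this result.

The compounds shown do not tell whether the number holds with a carboxylic acid or an amine on the chain at this place. They also leave open how a longer chain ending in neither ring nor polar group would read, as all three stop at benzyl or methyl.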